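The source may hold more compounds than are shown below. What is called first, only, known or untested is meant among the compounds shown, and "the series" means these compounds.

Measured so far:
- Compound 1, `COc1cc(/C=C/c2ccc(NC(=O)/C=C/c3cc(OC)c(OC)c(OC)c3)cc2)cc(OC)c1`: 2140 nM
- Compound 2, `COc1cc(/C=C/c2ccc(NC(=O)/C=C/c3ccc([N+](=O)[O-])cc3)cc2)cc(OC)c1`: 11700 nM

Both compounds were tested in a functional assay on MDA-MB-231 cells (Homo sapiens) for inhibition, read by MTT assay, with a stated time of 48 h; on this read-out lower numbers stand for stronger inhibition and higher numbers for weaker inhibition. Compound 2 gives the higher of the two numbers, 11700 nM. For the measured compounds named here, the only point of comparison is compound 1, which gives 2140 nM, a gap beyond the usual scatter, so compound 2 is the weaker inhibitor of the two.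

Compound 3, `COc1cc(/C=C/c2ccc(NC(=O)/C=C/c3ccc(Cl)cc3)cc2)cc(OC)c1`, is not yet measured. It differs from compound 2 in one place: chloro in place of nitro on an aromatic carbon. Going by the values given here, no measured pair shows this kind of swap, so its effect here is unknown. Given that, only a modest change in this assay is expected, leaning toward a somewhat lower number, most likely within or close to the scatter. Compound 3 is therefore estimated at 6000 nM, with a range from 2000 nM to 18000 nM. That expected step amounts to a 2.0-fold lower number from compound 2 to compound 3 (0.29 log units; within the scatter).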

Compound 3, half-maximal inhibitory concentration: 14100 nM
Beside the measured number, compound 3's estimate is 2.4-fold (0.37 log units) below it; low and high end bracket the measured number.
By their numbers in this assay, from the lowest: compound 1; then compounds 2 and 3 (each within the scatter of the next).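

In this assay, for the compounds shown here, the swap from 4-nitrophenyl to 4-chlorophenyl is the first change in a single place that can be read, and the two compounds cannot be told apart (the step is a 1.2-fold higher number from compound 2 to compound 3 (0.08 log units; within the scatter)). At this position, para to a large group, chloro therefore reads the same as nitro on this measure, although it has one heavy atom where nitro has three and lacks nitro's two hydrogen-bond acceptors. Nothing measured here explains why the two groups match.

The compounds shown leave open whether a group of another kind at this place, such as an amine or a carboxylic acid, would shift the number beyond the scatter. They also leave open how a plain hydrogen there would compare with nitro and chloro.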